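Bromo for methoxy on two cores of the series

The source may hold more compounds than are shown below. What is called first, only, known or untested is meant among the compounds shown, and "the series" means these compounds.

Compound 1 `C=C1C[C@]23C[C@@]1(O)CC[C@@H]2c1cccc(C)c1[C@@H]3Cn1cc(-c2ccc(OC)cc2)nn1` and compound 2 `C=C1C[C@]23C[C@@]1(O)CC[C@@H]2c1cccc(C)c1[C@@H]3Cn1cc(-c2ccc(Br)cc2)nn1` share one core; compound 3 `C=C1C(=O)[C@]23C[C@@]1(O)CC[C@H]2c1ccc(O)c(C)c1[C@@H]3Cn1cc(-c2ccc(OC)cc2)nn1` and compound 4 `C=C1C(=O)[C@]23C[C@@]1(O)CC[C@H]2c1ccc(O)c(C)c1[C@@H]3Cn1cc(-c2ccc(Br)cc2)nn1` share another, and the difference between the two cores is not broken down here. In a functional assay on HL-60 cells (Homo sapiens) for cytotoxicity, read by MTT assay, with a stated time of 4 days (a higher number here means a weaker inhibitor, a lower number a stronger inhibitor), compound 1 gives only a limit, > 20000 nM. Compound 2 likewise gives only a limit in this assay, > 20000 nM. The change bromo in place of methoxy on an aromatic carbon thus shows a step that the two limits leave unreadable from compound 1 to compound 2, and the limit of > 20000 nM in this assay, at which 2 of the 3 values shown sit, is all that can be read from it. For the measured compounds named here, compound 3 gives 1150 nM in this assay, the only number in the set. Compound 4 carries the same change, (bromo in place of methoxy on an aromatic carbon), whose size the earlier pair does not reveal. A step of a 1.3-fold higher number from compound 3 to compound 4 (0.12 log units; within the scatter) is expected, since compound 3 at 1150 nM is the only anchor. Compound 4 is expected near 1500 nM, between 400 nM and 6000 nM.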

Compound 4, half-maximal inhibitory concentration: 560 nM
For compound 4 the middle estimate is 2.7-fold (0.43 log units) above the measured one; low and high end bracket the measured number.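

In this assay, bromo in place of methoxy on an aromatic carbon gives a 2.1-fold lower number from compound 3 to compound 4 (0.31 log units; beyond the scatter) on the core of compound 3. This is one readable step on one core, so it does not show that the change carries from one core to another. The matching pair on the core of compound 1 cannot be read, and no size can be set against the step on the other core: the limit of > 20000 nM in this assay, at which 2 of the 4 values shown sit.

The compounds shown leave open how an amine or a carboxylic acid at the same aromatic carbon would read on either core. They also leave open which of the differences between the two cores goes with the readable values.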